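From Hydroxylated Hydrazones to a Dichlorophenyl Analogue

This account rests on a few compounds, and the source may have more. Where it says the series, first, only, none or still open, it means among the compounds named here.

Of the compounds shown here, three built on one shared core have been measured in an ADME assay on THP-1 cells (Homo sapiens) for cytotoxicity; on this read-out lower numbers stand for stronger inhibition and higher numbers for weaker inhibition. Compound 1 `COc1ccccc1-c1nnc(-c2ccc(C(=O)N/N=C/c3cccc(O)c3O)cc2)o1` gives 102000 nM. Compound 2 `COc1ccccc1-c1nnc(-c2ccc(C(=O)N/N=C/c3cc(O)ccc3O)cc2)o1` gives 100000 nM, and a 1.0-fold lower number from compound 1 to compound 2 (0.01 log units; within the scatter). Compound 3 `COc1ccc(O)c(/C=N/NC(=O)c2ccc(-c3nnc(-c4ccccc4OC)o3)cc2)c1` gives 303000 nM, the highest of the three numbers; both a 3.0-fold higher number from compound 1 to compound 3 (0.47 log units; beyond the scatter) and a 3.0-fold higher number from compound 2 to compound 3 (0.48 log units; beyond the scatter) set compound 3 apart from the other two beyond the scatter.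

Compound 4 `COc1ccccc1-c1nnc(-c2ccc(C(=O)N/N=C/c3ccc(Cl)cc3Cl)cc2)o1` has not yet been measured. It differs from compound 3 in one place: 2,4-dichlorophenyl in place of 2-hydroxy-5-methoxyphenyl on a carbon with a double bond to nitrogen. For the measured compounds named here, no measured step exchanges a ring bearing oxygen for one bearing chlorine, so the two steps ending at compound 3 are the only guide, and they show merely that methyl in place of hydrogen on an oxygen on an aromatic ring raised the number modestly. Going by the values given here, the entering 2,4-dichlorophenyl carries no hydrogen-bond donor or acceptor, a situation none of the measured compounds covers, so the direction of the coming step is uncertain. For compound 4 the expected step is a 2.0-fold lower number from compound 3 to compound 4 (0.31 log units; beyond the scatter). Compound 4 is therefore estimated at 150000 nM, with a range from 50000 nM to 450000 nM, placing it nearer the numbers of compound 1 and compound 2 than to compound 3.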

Compound 4, half-maximal inhibitory concentration: 78800 nM
The estimate for compound 4 lay 1.9-fold (0.28 log units) above the measured number, and the stated range covers the measured number.
By their numbers in this assay, from the lowest: compounds 4, 2 and 1 (each within the scatter of the next); then compound 3.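

In this assay, a ring with no hydrogen-bond donors or acceptors on the carbon with a double bond to nitrogen falls in with the hydroxylated rings: 2,4-dichlorophenyl in place of 2,5-dihydroxyphenyl gives a 1.3-fold lower number from compound 2 to compound 4 (0.10 log units; within the scatter), and 2,4-dichlorophenyl in place of 2,3-dihydroxyphenyl gives a 1.3-fold lower number from compound 1 to compound 4 (0.11 log units; within the scatter). Against the 2-hydroxy-5-methoxyphenyl ring the same group gives a 3.8-fold lower number from compound 3 to compound 4 (0.58 log units; beyond the scatter), so among these four compounds only compound 3 stands apart, and the two hydroxyl groups of compound 1 and compound 2 prove unnecessary for numbers of this size. Nothing available explains why compound 3 alone separates from the other three.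

The compounds shown leave open whether an amine or a carboxylic acid on this ring would stay with compounds 1, 2 and 4 or move away from them, and whether a single chlorine would behave as the two do here. They also leave open whether a longer chain on the oxygen, such as ethoxy in place of the methoxy of compound 3, would take the number further in the same direction.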